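Swapping the aminocyclohexyl for a piperidinyl on the ether chain

The compounds below may be only part of what the source reports. "The series", "measured", "known", "first", "only" and "open" are said of these compounds alone.

Compound 1 `Cn1nc(-c2ccc(OC[C@H]3CC[C@H](N)CC3)c(F)c2)c2cnc(N)nc21`: 1400 nM
Compound 2 `Cn1nc(-c2ccc(OC[C@H]3CC[C@@H](N)CC3)c(F)c2)c2cnc(N)nc21`: 2200 nM

In an assay on tissue (PBMC cells) for antagonist activity at Toll-like receptor 9 (Homo sapiens) (on this read-out higher numbers stand for weaker inhibition and lower numbers for stronger inhibition), compound 1 gives 1400 nM, and compound 2 gives 2200 nM. The two numbers sit close together, a 1.6-fold higher number from compound 1 to compound 2 (0.20 log units; within the scatter), so compound 2 cannot be set apart from compound 1 on this read-out; the pair differs only in the configuration as drawn, (the fact that compounds 1 and 2 differ only in the configuration as drawn).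

Compound 3 `Cn1nc(-c2ccc(OCC3CCNCC3)c(F)c2)c2cnc(N)nc21` is not yet measured. It differs from compound 2 by piperidin-4-yl in place of 4-aminocyclohexyl on a saturated chain carbon bound to an oxygen on an aromatic ring. Among the measured compounds shown here, the only measured step, a 1.6-fold higher number from compound 1 to compound 2 (0.20 log units; within the scatter), concerns a change of configuration alone and leaves the atoms and bonds untouched, so it says nothing about exchanging one saturated ring for another. For the measured compounds named here, no measured step bears directly on the change from compound 2 to compound 3. With the ring amine kept but the ring shortened by one atom and the stereocentres gone, a moderate shift is expected, most likely toward a somewhat higher number, with the expected step from compound 2 to compound 3 being a 1.4-fold higher number from compound 2 to compound 3 (0.13 log units; within the scatter). Compound 3 is therefore estimated at 3000 nM in this assay, with a range from 1000 nM to 9000 nM.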

Compound 3, half-maximal inhibitory concentration: 3400 nM
Compound 3: middle estimate off by 1.1-fold (0.05 log units), on the low side; the range from low to high includes it.
By their numbers in this assay, from the lowest: compounds 1, 2 and 3 (each within the scatter of the next, the first and the last beyond it).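

In this assay, among the compounds shown here, compound 3 gives the first reading of a change to the atoms themselves: the nitrogen that sat outside the ring as an amine in 4-aminocyclohexyl is a ring member in piperidin-4-yl, on a saturated chain carbon bound to an oxygen on an aromatic ring. One reading, a 1.5-fold higher number from compound 2 to compound 3 (0.19 log units; within the scatter), cannot be told apart from no change, while the other, a 2.4-fold higher number from compound 1 to compound 3 (0.39 log units; beyond the scatter), is a real but modest change. This exchange of rings therefore brings no gain in inhibition and costs little, and the two readings differ only in their starting point: the fact that compounds 1 and 2 differ only in the configuration as drawn

As far as these compounds go, what stays open is whether the amine is needed at all, which a plain cyclohexyl ring could test, and whether a methyl group on the piperidine nitrogen would shift the number. From the compounds shown here alone, how a longer chain, such as (piperidin-4-yl)ethoxy in place of (piperidin-4-yl)methoxy, would read in this assay is also still open.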